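The source may report more compounds than this note shows. Statements on the series, on what has been measured and on what is new or still open speak of the compounds shown alone.

In a functional assay on MGC-803 cells (Homo sapiens) for cytotoxicity, read by MTT assay, with a stated time of 72 h (a lower number here means a stronger inhibitor, a higher number a weaker inhibitor), compound 1 `CCCCCCNc1nc(SCc2ccc(C(F)(F)F)cc2)nc2ccccc12` gives 13100 nM. Compound 2 `CCCCCCCCNc1nc(SCc2ccc(C(F)(F)F)cc2)nc2ccccc12` gives 12600 nM in this assay. Compound 3 `CCCCCCCCCCCCNc1nc(SCc2ccc(C(F)(F)F)cc2)nc2ccccc12` reaches only the limit of this assay, > 50000 nM, and no number is known for it. Compound 3 therefore sits at the limit of > 50000 nM in this assay, at which 1 of the 3 values shown sits, the weakest position among the three measured compounds, as the steps of an at least 3.8-fold higher number from compound 1 to compound 3 (0.58 log units; beyond the scatter) and an at least 3.9-fold higher number from compound 2 to compound 3 (0.59 log units; beyond the scatter) show, while a 1.0-fold lower number from compound 1 to compound 2 (0.02 log units; within the scatter) leaves the two shorter chains side by side. Compound 4 `CCCCCCCCCCCCCCNc1nc(SCc2ccc(C(F)(F)F)cc2)nc2ccccc12` differs from compound 3 by ethyl in place of hydrogen on a saturated chain carbon, ten or more bonds along the chain from a nitrogen on an aromatic ring, a further lengthening of the same chain. Among the measured compounds shown here, the two measured steps that lengthen that chain toward compound 3 both pointed in the same direction and were at least modest, and no measured step runs the other way from a limit back to a number. For compound 4 the expected step is a step that the limit leaves unreadable from compound 3 to compound 4, a further weakening or at best no change beyond the scatter, with this assay most likely reporting only its limit once more. Compound 4 is estimated to give 90000 nM in this assay, within a range from 35000 nM to 300000 nM.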

Compound 4, half-maximal inhibitory concentration: > 50000 nM
Compound 4: a limit, no number; the forecaster's own chance of this, stated with the estimate: 85%; the middle value is on the limit's open side.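

In this assay compound 4 gives > 50000 nM, a limit of the assay and not a number, so the step that adds ethyl to the chain of compound 3 cannot be read, and the two longest chains now stand at one shared limit: the limit of > 50000 nM in this assay, at which 2 of the 4 values shown sit.

What compound 4 adds is that the weak result does not belong to the chain of compound 3 alone, since the further lengthened chain also stays clearly apart from the two shorter ones, with an at least 3.9-fold higher number from compound 2 to compound 4 (0.59 log units; beyond the scatter) and an at least 3.8-fold higher number from compound 1 to compound 4 (0.58 log units; beyond the scatter). These steps match those seen earlier for the lengthening to compound 3, though only as limits: the same change on two cores in this assay, an at least 3.8-fold higher number (0.58 log units; beyond the scatter) from compound 1 to compound 3 and an at least 3.9-fold higher number (0.59 log units; beyond the scatter) from compound 2 to compound 4; the limit leaves it open whether they differ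

On these data alone, how far compound 3 and compound 4 lie past the limit, and whether they differ from each other at all, stays open. As far as these compounds go, it also stays open whether a decyl chain would sit with compound 1 and compound 2 or with compound 3 and compound 4, and what an amine or a carboxylic acid on this chain would do in this assay.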